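Replacing the Acetyl on the Piperidine Nitrogen

This account rests on a few compounds, and the source may have more. Where it says the series, first, only, none or still open, it means among the compounds named here.

Compound 1 `CC(=O)N1CCC(c2cc3c(-c4ccc(=O)n(C(C)C)c4)ccnc3[nH]2)CC1` is one of three compounds whose removal rate has been measured in an ADME assay on cells (Hepatocyte, Rattus norvegicus) for metabolic stability; a higher number here means faster removal of the compound, a lower number slower removal. In this assay compound 1 gives 2.8 uL/min, the lowest of the three numbers. Among the measured compounds shown here, compound 2 `CC(C)n1nc(-c2ccnc3[nH]c(C4CCN(CC(=O)N(C)C)CC4)cc23)ccc1=O` gives 3.1 uL/min, a value that sits within the usual scatter of the one for compound 1, so the two cannot be told apart. Compound 3 `COc1cc(C(=O)N2CCCC2)ccc1-c1ccnc2[nH]c(C3CCOCC3)cc12` gives 15 uL/min, which lies beyond the scatter above compound 1.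

Compound 4 `CC(C)n1cc(-c2ccnc3[nH]c(C4CCN(CC(=O)N5CCCCC5)CC4)cc23)ccc1=O` has not yet been measured. It differs from compound 1 in one place: ((piperidin-1-yl)carbonyl)methyl in place of acetyl on an amine nitrogen in a ring. For the measured compounds named here, no pair of measured compounds shows the effect of exactly this change. Still, compound 2 also carries an amide-bearing group in place of the acetyl and gives 3.1 uL/min, a number indistinguishable from that of compound 1. On that basis the step from compound 1 to compound 4 is expected to be small and upward, a 1.8-fold higher number from compound 1 to compound 4 (0.25 log units; within the scatter), most likely not far beyond the scatter. Compound 4 is therefore expected to give about 5 uL/min in this assay, with a likely range from 2 uL/min to 13 uL/min.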

Compound 4, intrinsic clearance in a liver preparation (reported as CLH), per the amount of preparation that the assay uses: 26 uL/min
Estimate against measurement, compound 4: 5.2-fold (0.72 log units) below; measured number outside the range, above it.
By their numbers in this assay, from the lowest: compounds 1 and 2 (each within the scatter of the next); then compounds 3 and 4 (each within the scatter of the next).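

This step shows that the amine nitrogen in a ring is sensitive to what it carries: ((piperidin-1-yl)carbonyl)methyl in place of acetyl brings a 9.3-fold higher number from compound 1 to compound 4 (0.97 log units; beyond the scatter) in this assay. The two groups have the same counts of hydrogen-bond donors and acceptors and no net charge, but the one that enters is larger and adds a six-membered non-aromatic ring, so matching those counts did not keep the number low. Nothing shown gives a reason for this rise.

As far as these compounds go, it remains open whether the step comes from the added ring or from the longer link between the amine nitrogen and the carbonyl. Also unknown is how the number would respond on the core of compound 1 to a morpholine amide, a simple tertiary amine or a carboxylic acid at this position.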